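The source may report more compounds than this note shows. Statements on the series, on what has been measured and on what is new or still open speak of the compounds shown alone.

Measured so far in a functional assay for activation of Alpha-1B adrenergic receptor (Homo sapiens), read by calcium flux; on this read-out higher numbers stand for an effect only at larger amounts of compound and lower numbers for an effect already at smaller amounts:
compound 3 `c1csc(-c2ccccc2OCC2=NCCN2)c1`: 3.98 nM
compound 1 `CCN(CC)C(=O)c1ccccc1OCC1=NCCN1`: < 5020 nM
compound 2 `Cc1ccnc(-c2ccccc2OCC2=NCCN2)c1`: < 100000 nM

Among the compounds with values here, compound 3 stands as the only compound with an actual number in this assay; its value of 3.98 nM is therefore the sole fixed point of the series. For compound 1 the assay reports only a limit, < 5020 nM, and not a number. For compound 2 likewise the result is a limit, < 100000 nM, and gives no number. Neither limit can be placed relative to compound 3 beyond saying that both lie on the side of larger amounts of compound. Within the data shown here, no pair of measured compounds differs in a single place, so no measured step is available to calibrate the change that follows.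

Compound 4 `Cc1ccoc1-c1ccccc1OCC1=NCCN1` is the next compound to be measured in this assay. It differs from compound 3 by 3-methylfuran-2-yl in place of thiophen-2-yl on an aromatic carbon. The swap keeps a five-membered aromatic ring with one hetero atom in the same place and adds a methyl on it. Among the measured compounds shown here, with no measured step to lean on, the expected step is a 2.5-fold higher number from compound 3 to compound 4 (0.40 log units; beyond the scatter), a modest move toward larger amounts of compound, likely near the edge of the usual scatter. Compound 4 is therefore estimated at 10 nM, with a range from 2.5 nM to 60 nM.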

Compound 4, half-maximal effective concentration: < 100000 nM
Compound 4: a limit, no number; the forecaster's own chance of this, stated with the estimate: 5%; the middle value is on the limit's open side.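

Compound 4 gives only a limit in this assay, < 100000 nM, and not a number. The step from compound 3 to compound 4 therefore cannot be read. The compounds shown leave open where compound 4 actually stands in this assay, and whether the 3-methylfuran-2-yl ring itself or its methyl matters in place of thiophen-2-yl.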